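Swapping Acetyl for Iodo: What to Expect

This account rests on a few compounds, and the source may have more. Where it says the series, first, only, none or still open, it means among the compounds named here.

Measured so far:
compound 1 `Cc1cccc(NC(=O)N[C@@H](C)c2ccccc2)c1` — in an ADME assay on the whole organism with Oryza sativa as the target, tested at 0.1 uM (a higher number here means a weaker effect of the compound at the concentration tested, a lower number a stronger effect), compound 1 gives 99%
compound 2 `COc1cccc(NC(=O)N[C@@H](C)c2ccccc2)c1` — in this assay compound 2 gives 101%
compound 3 `CC(=O)c1cccc(NC(=O)N[C@@H](C)c2ccccc2)c1` — in this assay compound 3 gives 96%

The three compounds share one core and differ only in a single group on an aromatic ring. Their readings in this assay sit close together: the step of a number 2 percentage points higher from compound 1 to compound 2 (within the scatter) lies within the scatter, as do the steps of a number 3 percentage points lower from compound 1 to compound 3 (within the scatter) and a number 5 percentage points lower from compound 2 to compound 3 (within the scatter). Compound 3 therefore stands alongside the other two; its number cannot be told apart from theirs by this kind of measurement.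

Compound 4 `C[C@H](NC(=O)Nc1cccc(I)c1)c1ccccc1` has not yet been tested. Its structure differs from compound 3 in one place: iodo in place of acetyl on an aromatic carbon. The measured steps that bear on this are the two in which acetyl enters, a number 3 percentage points lower from compound 1 to compound 3 (within the scatter) and a number 5 percentage points lower from compound 2 to compound 3 (within the scatter), and both were within the scatter. Among the compounds with values here, no measured step involves iodo at all, so nothing shows what that group does here.

On this basis the step to compound 4 is expected to stay within the scatter, a number 2 percentage points higher from compound 3 to compound 4 (within the scatter). Compound 4 is estimated to give 98% in this assay, with a likely range from 88% to 108%.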

Compound 4, a percentage reported as activity, at one concentration (the size of the read-out at that concentration, not a potency): 98%
Beside the measured number, compound 4's estimate shows no gap at the digits printed; the range from low to high includes it.
By their numbers in this assay, from the lowest: compounds 3, 4, 1 and 2 (each within the scatter of the next).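

In this assay iodo now joins methyl, methoxy and acetyl on the same aromatic carbon, and its reading cannot be told apart from any of theirs: against acetyl (a number 2 percentage points higher from compound 3 to compound 4 (within the scatter)), against methoxy (a number 3 percentage points lower from compound 2 to compound 4 (within the scatter)) and against methyl (a number 1 percentage points lower from compound 1 to compound 4 (within the scatter)). The change is also a real difference in build, since acetyl, with 3 heavy atoms and 1 hydrogen-bond acceptor, gives way to iodo, with 1 heavy atom and 0 hydrogen-bond acceptors, yet no separable shift in the reading follows, so all four groups at this place on the ring now give results that this kind of measurement cannot separate. Nothing available explains why the reading holds across these groups.

The compounds shown leave open whether an amine, a carboxylic acid or a longer alkyl chain on this aromatic carbon would move the reading beyond the scatter. They also leave open whether these four compounds would still be indistinguishable at a higher concentration than the single one tested here.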